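Swapping the Aryl Group on a Sulfonyl Sulfur

The source may report more compounds than this note shows. Statements on the series, on what has been measured and on what is new or still open speak of the compounds shown alone.

Compound 1, `CC1CCN(C2CCN(S(=O)(=O)c3cccnc3F)CC2)CC1`: > 10000 nM
Compound 2, `COc1ccc(NC(=O)N2CCC(N3CCC(C)CC3)CC2)cc1`: > 5000 nM

In an ADME assay on HCT-116 cells (Homo sapiens) for cytotoxicity, read by CellTiter-Glo, with a stated time of 72 h (on this read-out lower numbers stand for stronger inhibition and higher numbers for weaker inhibition), compound 1 gives > 10000 nM, which is a limit of the assay and not a number, as the limit of > 10000 nM in this assay, at which 1 of the 2 values shown sits, shows. Compound 2 likewise returns only a limit in this assay, > 5000 nM, noted in the limit of > 5000 nM in this assay, at which 1 of the 2 values shown sits. Compound 3, `CC1CCN(C2CCN(S(=O)(=O)c3ccc(F)cc3F)CC2)CC1`, awaits measurement; it differs from compound 1 in one place: 2,4-difluorophenyl in place of 2-fluoropyridin-3-yl on a sulfonyl sulfur. Within the data shown here, no measured step between measured compounds exists here, so a change no larger than the usual scatter is expected; the estimated step is a step that the limit leaves unreadable from compound 1 to compound 3. Compound 3 is expected at 20000 nM, within 5000 nM to 80000 nM.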

Compound 3, half-maximal inhibitory concentration: > 5000 nM
Compound 3: a limit, no number; the forecaster's own chance of this, stated with the estimate: 85%; the middle value does not contradict the limit.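

Among these compounds, compound 1 and compound 3 each return only a limit of the assay, not a number, so no step between them can be read. The compounds shown leave open whether 2,4-difluorophenyl in place of 2-fluoropyridin-3-yl changes the result in this assay at all.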